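Carboxy in place of fluoro on the aryloxy ring

The compounds below may be only part of what the source reports. "The series", "measured", "known", "first", "only" and "open" are said of these compounds alone.

Going by the values given here, compound 1 `CCN(Cc1cccs1)C(=O)COc1ccc(F)cc1` gives 422 nM in an assay on HEK293 cells for agonist activity at transient receptor potential cation channel subfamily M member 8 (Homo sapiens), read by fluorescence and calcium flux, with a stated time of 15 min (on this read-out lower numbers stand for an effect already at smaller amounts and higher numbers for an effect only at larger amounts of compound), the highest of the three numbers measured so far. Compound 3 `CCN(Cc1ccc(C)s1)C(=O)COc1ccc(C)cc1` gives 178 nM, a step beyond the scatter below compound 1, and compound 2 `CCN(Cc1cccs1)C(=O)COc1ccc2c(c1)CCC2` gives 0.8 nM, far below both. Compound 4 `CCN(Cc1cccs1)C(=O)COc1ccc(C(=O)O)cc1` carries carboxy in place of fluoro on an aromatic carbon. Among the compounds with values here, its value in this assay is not yet known, and no measured pair shows this change, nor does any measured compound carry a carboxy at all, so the expectation rests on compound 1 alone. The number is estimated to rise from compound 1 by a 14-fold higher number from compound 1 to compound 4 (1.15 log units; beyond the scatter). Compound 4 is expected at 6000 nM, with a range from 1500 nM to 30000 nM, and it is possible that only a limit is reported.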

Compound 4, half-maximal effective concentration: "not active" (no number reported)
No number was reported for compound 4, so the estimate cannot be set against anything.
By their numbers in this assay, from the lowest: compound 2; then compound 3; then compound 1.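

Going by these compounds alone, compound 4 is reported as not active, without a number, so no step from compound 1 can be read. The compounds shown leave open how carboxy in place of fluoro would read elsewhere in the series. No measurement shown accounts for this result.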